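A few compounds are considered here, and "the series" means these few. Any claim that something is new, unique, unknown or untested is made for them only; others in the source may bear on it.

In a functional assay on the whole organism for inhibition, with Rattus norvegicus as the target, at a dose of 10 mg/kg by the oral route (a lower number here means a weaker effect, a higher number a stronger effect of the compound at the dose given), compound 1 `COc1cc(C(=O)Nc2nn[nH]n2)nc(-c2ccccc2)c1` gives 100%, while compound 2 `O=C(Nc1nn[nH]n1)c1cccc(-c2ccccc2)n1` gives 81%. Among the compounds with values here, compound 2 thus holds the lower of the two numbers measured so far, and the only step between them, a number 19 percentage points lower from compound 1 to compound 2 (beyond the scatter), came with a hydrogen in place of methoxy on an aromatic carbon. Within the data shown here, compound 3 `COc1ccccc1-c1cccc(C(=O)Nc2nn[nH]n2)n1` has not yet been measured in this assay. methoxy in place of hydrogen on an aromatic carbon This change reverses the one measured step in kind, but places the methoxy on a different ring, so the step from compound 1 to compound 2 bears on it only loosely and its size cannot be carried over with confidence. A gain seems possible for compound 3, though nothing measured fixes how large. Compound 3 is therefore expected to return 88%, within a range from 70% to 100%, which means an expected step of a number 7 percentage points higher from compound 2 to compound 3 (within the scatter).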

Compound 3, a percentage reported as inhibition, in the whole organism at one dose (the size of the read-out at that dose, not a potency): 0%
Estimate against measurement, compound 3: 88 percentage points above; measured number below the stated range.
By their numbers in this assay, from the lowest: compound 3; then compound 2; then compound 1.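

In this assay, methoxy in place of hydrogen on this carbon, ortho to a large group on a six-membered aromatic ring of carbon only, brings a number 81 percentage points lower from compound 2 to compound 3 (beyond the scatter). The earlier step, hydrogen in place of methoxy at a different place, gave a number 19 percentage points lower from compound 1 to compound 2 (beyond the scatter), so the same group can go with a higher or a far lower number depending on where it stands, and this position is the first shown where adding a group removes the effect at this dose. Nothing available bears on what lies behind this loss.

The compounds shown leave open whether the loss belongs to methoxy itself or would follow any group at this place. A fluorine or a methyl on the same carbon would separate these two readings, and methoxy on another carbon of that ring would show how narrow the sensitive spot is.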